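The compounds below may be only part of what the source reports. "The series", "measured", "known", "first", "only" and "open" are said of these compounds alone.

Working notes on the series. Among the measured compounds shown here, compound 1 `Cc1ccc(S(=O)(=O)Oc2c(-c3ccccc3)c(-c3ccccc3)n3ccc(C#N)cc23)cc1` is the only member with a full result: in an assay for inhibition of Polyunsaturated fatty acid lipoxygenase ALOX15 (Oryctolagus cuniculus) (on this read-out higher numbers stand for weaker inhibition and lower numbers for stronger inhibition), compound 1 gives 25000 nM. Compound 2 `COc1cccc(-c2c(-c3ccccc3)c(-c3ccccc3)n3ccc(C#N)cc23)c1` has no reported result in this assay ("not determined" (no result reported)). Compound 3 `N#Cc1ccn2c(-c3ccccc3)c(-c3ccccc3)c(OCc3ccc(Cl)cc3)c2c1` likewise stands without a number in this assay ("not determined" (no result reported)); the only measured reference point for the series is compound 1. Compound 4 `N#Cc1ccn2c(-c3ccccc3)c(-c3ccccc3)c(Cc3ccccc3)c2c1` is the next member, not yet measured. It differs from compound 3 in one place (benzyl in place of (4-chlorobenzyl)oxy on an aromatic carbon). For the measured compounds named here, with no numerical result for compound 3, no measured step can be drawn, and the expectation rests on compound 1 alone; no shift beyond the usual scatter of this assay is expected in either direction. Compound 4 is estimated at 25000 nM in this assay, within a range of 6000 nM to 100000 nM.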

Compound 4, half-maximal inhibitory concentration: 46000 nM
Estimate against measurement, compound 4: 1.8-fold (0.26 log units) below, and the stated range covers the measured number.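

This position now has two measured groups: in this assay, benzyl in place of ((4-methylphenyl)sulfonyl)oxy on the aromatic carbon gives a 1.8-fold higher number from compound 1 to compound 4 (0.26 log units; within the scatter) and so the two groups are not told apart by this read-out. Both groups carry a six-membered aromatic ring of carbon only, so this pair says nothing about a group without one. No measured evidence bears on this result. Open, on these data alone, is whether an amine or a carboxylic acid on this carbon would give a number beyond the scatter.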